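A few compounds are considered here, and "the series" means these few. Any claim that something is new, unique, unknown or untested is made for them only; others in the source may bear on it.

Working notes on the series in an ADME assay on CCRF-CEM cells (Homo sapiens) for cytotoxicity, with a stated time of 72 h; a lower number here means a stronger inhibitor, a higher number a weaker inhibitor.

Compound 1 `Clc1ccc(Cc2nn3c(Br)c(-c4ccccc4)nc3s2)cc1` carries a bromo group on the shared core and a plain phenyl. In this assay compound 1 gives > 250000 nM, which is a limit of the measurement and not a number. Compound 2 `O=[N+]([O-])c1ccc(-c2nc3sc(Cc4ccc(Cl)cc4)nn3c2Br)cc1` differs from compound 1 by nitro in place of hydrogen on an aromatic carbon, and in this assay compound 2 gives 73000 nM. The step of an at least 3.4-fold lower number from compound 1 to compound 2 (0.53 log units; beyond the scatter) rests on a limit, as the limit of > 250000 nM in this assay, at which 1 of the 3 values shown sits, shows. Compound 3 `O=Cc1c(-c2ccccc2)nc2sc(Cc3ccc(Cl)cc3)nn12` differs from compound 1 by formyl in place of bromo on an aromatic carbon, a change of the core itself. In this assay compound 3 gives 22000 nM, which makes the step of an at least 11-fold lower number from compound 1 to compound 3 (1.05 log units; beyond the scatter). Going by the values given here, of the two numbers known, compound 3 holds the lower one, with compound 2 a step above it.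

Compound 4 `O=Cc1c(-c2ccc([N+](=O)[O-])cc2)nc2sc(Cc3ccc(Cl)cc3)nn12` has not been measured. It differs from compound 3 by nitro in place of hydrogen on an aromatic carbon, the same change as that from compound 1 to compound 2, made here on the formyl-bearing core rather than the bromo-bearing one; the place of the change reads the same in both cases. The step of a 3.1-fold lower number from compound 3 to compound 4 (0.50 log units; beyond the scatter) is expected to be close in size to the earlier one, because the step of an at least 3.4-fold lower number from compound 1 to compound 2 (0.53 log units; beyond the scatter) was at least modest and stands on a limit, so its true size may be larger. Compound 4 is therefore expected to give 7000 nM in this assay, with a likely range from 2500 nM to 25000 nM.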

Compound 4, half-maximal inhibitory concentration: 13000 nM
Compound 4: middle estimate off by 1.9-fold (0.27 log units), on the low side; the range from low to high includes it.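

On the formyl-bearing core in this assay, nitro in place of hydrogen gives a 1.7-fold lower number from compound 3 to compound 4 (0.23 log units; within the scatter), and on the 4-nitrophenyl compounds formyl in place of bromo gives a 5.6-fold lower number from compound 2 to compound 4 (0.75 log units; beyond the scatter). Set beside the step on the bromo-bearing core, the nitro change is beyond the scatter there and within it here, yet this does not show that its size depends on the core: the same change on two cores in this assay, an at least 3.4-fold lower number (0.53 log units; beyond the scatter) from compound 1 to compound 2 and a 1.7-fold lower number (0.23 log units; within the scatter) from compound 3 to compound 4; the limit leaves it open whether they differ. The formyl change lies beyond the scatter and runs to a lower number with either phenyl or 4-nitrophenyl, so its direction carries over in these two pairs, but whether its size carries over is not shown: the same change on two cores in this assay, an at least 11-fold lower number (1.05 log units; beyond the scatter) from compound 1 to compound 3 and a 5.6-fold lower number (0.75 log units; beyond the scatter) from compound 2 to compound 4; the limit leaves it open whether they differ.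

Only bromo and formyl on the core and only hydrogen and nitro on the phenyl ring are shown, so it remains open whether another group at that place on the phenyl ring, such as an amine or a carboxylic acid, would behave as nitro does on either core. On these data alone, it is also open whether the formyl step would hold for a carboxylic acid or a longer chain in place of formyl.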